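This account rests on a few compounds, and the source may have more. Where it says the series, first, only, none or still open, it means among the compounds named here.

Measured so far in a functional assay on HEL cells (Homo sapiens), read by microscopy; on this read-out higher numbers stand for lower toxicity in this test and lower numbers for higher toxicity in this test:
compound 1, `O=c1nc2occc2cn1COCCO`: > 400000 nM
compound 2, `CCCCCc1cc2cn(COCCO)c(=O)nc2o1`: > 400000 nM
compound 3, `OCCOCn1cc2ccnc-2nc1O`: > 400000 nM

In this assay compound 1 returns only a limit of the assay, > 400000 nM, and not a number. Compound 2 likewise stops at a limit, > 400000 nM. Compound 3 also gives a limit, > 400000 nM. The change from compound 1 to compound 2 is pentyl in place of hydrogen on an aromatic carbon; its step, a step that the two limits leave unreadable from compound 1 to compound 2, cannot be read because of the limit of > 400000 nM in this assay, at which 3 of the 3 values shown sit. The core of compound 3 differs from the core of compound 1 in a way that is not broken down here. Compound 4, `CCCCCc1cc2cn(COCCO)c(O)nc-2n1`, is still to be measured; it differs from compound 3 by pentyl in place of hydrogen on an aromatic carbon. This is the same kind of change as that from compound 1 to compound 2, but the place differs: in compound 2 the aromatic carbon belongs to a five-membered aromatic ring with 1 oxygen, next to the ring oxygen, while in compound 4 it belongs to a five-membered aromatic ring with 1 nitrogen, next to the ring nitrogen. The step from compound 3 to compound 4 is expected to be a number no higher from compound 3 to compound 4 (the limit leaves the size open), set beside the unreadable earlier step. This expectation rests on (the limit of > 400000 nM in this assay, at which 3 of the 3 values shown sit), nothing more. Compound 4 is therefore estimated at 400000 nM, most likely reported again as a limit.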

Compound 4, minimum cytotoxic concentration: > 400000 nM
Compound 4: a limit, no number (the forecaster's own chance of this, stated with the estimate: 80%); the middle value sits exactly at the limit.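

In this assay compound 4 gives > 400000 nM, a limit and not a number. No new step can be read for compound 3 and compound 4, as both stop at a limit: the limit of > 400000 nM in this assay, at which 4 of the 4 values shown sit.

The compounds shown leave open what number any of the four would give, and whether pentyl in place of hydrogen on an aromatic carbon shifts it on either core.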